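This account rests on a few compounds, and the source may have more. Where it says the series, first, only, none or still open, it means among the compounds named here.

Of the compounds shown here, three that share one core have been tested in an assay on CHO cells for inhibition of Glucagon receptor (Homo sapiens), tested at 20 uM; a lower number here means less inhibition, a higher number more inhibition at the concentration tested (going by the name of the read-out). Compound 1 `CCCCCc1c(C(C)C)nc(C(C)C)c(CO)c1-c1ccccc1CO` gives 44%. Compound 2 `CCCCCc1c(C(C)C)nc(C(C)C)c(CO)c1-c1cccc(Cl)c1` gives 49%. Compound 3 `CCCCCc1c(C(C)C)nc(C(C)C)c(CO)c1-c1ccc(Cl)cc1Cl` gives 8%, the lowest of the three numbers, and its distance to each of the others lies beyond the scatter: a number 36 percentage points lower from compound 1 to compound 3 (beyond the scatter) and a number 41 percentage points lower from compound 2 to compound 3 (beyond the scatter). The step of a number 5 percentage points higher from compound 1 to compound 2 (within the scatter) shows that a 3-chlorophenyl and a 2-(hydroxymethyl)phenyl on that carbon give readings that cannot be told apart.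

Compound 4 `CCCCCc1c(C(C)C)nc(C(C)C)c(CO)c1-c1ccc(CC)cc1` has not yet been measured. It differs from compound 3 in one place: 4-ethylphenyl in place of 2,4-dichlorophenyl on an aromatic carbon. Both measured steps that brought in the 2,4-dichlorophenyl were large downward steps; the step toward compound 4 goes the other way and removes that group again. Among the measured compounds shown here, no measured compound carries a 4-ethylphenyl, so the size of the step remains uncertain, but compound 1 and compound 2, each with a singly substituted phenyl, both stand far above compound 3. For compound 4 a large upward step in this assay is therefore expected, a number 32 percentage points higher from compound 3 to compound 4 (beyond the scatter). Compound 4 is estimated at 40%, with a range from 15% to 62%.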

Compound 4, a percentage reported as inhibition, at one concentration (the size of the read-out at that concentration, not a potency): 42%
Beside the measured number, compound 4's estimate is 2 percentage points below it; low and high end bracket the measured number.
By their numbers in this assay, from the lowest: compound 3; then compounds 4, 1 and 2 (each within the scatter of the next).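

In this assay the swap of one eight-atom group for another gives a clear change, a number 34 percentage points higher from compound 3 to compound 4 (beyond the scatter), so a substituted phenyl at this carbon, opposite the ring nitrogen, need not give a low reading. The remaining comparisons are a number 7 percentage points lower from compound 2 to compound 4 (within the scatter) and a number 2 percentage points lower from compound 1 to compound 4 (within the scatter), and both leave the readings indistinguishable, so 4-ethylphenyl, 3-chlorophenyl and 2-(hydroxymethyl)phenyl all sit at one level here, while among these four compounds only compound 3, with its 2,4-dichlorophenyl, stands apart. No other measurement is available to explain why the 2,4-dichlorophenyl behaves differently from the three singly substituted phenyls.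

On these data alone, whether one of the two chlorines alone is enough for the low reading remains open, and a 2-chlorophenyl and a 4-chlorophenyl would separate those two cases. Also open, as far as these compounds go, is whether the number in this assay would be higher, lower or level with other kinds of group at this position, such as a phenyl bearing an amine or a carboxylic acid, a longer chain in place of the ethyl, or a ring containing nitrogen in place of the phenyl.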